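The source may report more compounds than this note shows. Statements on the series, on what has been measured and on what is new or still open speak of the compounds shown alone.

Measured so far in a functional assay on OVCAR-3 cells (Homo sapiens) for inhibition, read by sulforhodamine B assay, with a stated time of 48 h; on this read-out higher numbers stand for weaker inhibition of growth and lower numbers for stronger inhibition of growth:
compound 1 `CC(C)c1ccc(Nc2ccc3c(OCCCN4CCN(C)CC4)cccc3n2)cc1` – 14400 nM
compound 2 `CN1CCN(CCCOc2cccc3nc(Nc4ccc(F)c(F)c4)ccc23)CC1` – 4580 nM

Among the measured compounds shown here, compound 1 stands at the highest number of the two; the single measured step, a 3.1-fold lower number from compound 1 to compound 2 (0.50 log units; beyond the scatter), is modest and replaces the same 4-isopropylphenyl with 3,4-difluorophenyl. Compound 3 `CN1CCN(CCCOc2cccc3nc(Nc4cccc(Cl)c4)ccc23)CC1` differs from compound 1 by 3-chlorophenyl in place of 4-isopropylphenyl on a nitrogen on an aromatic ring. For the measured compounds named here, only that one step bears on this change, so a modest lowering of the number is expected, of about a 2.4-fold lower number from compound 1 to compound 3 (0.38 log units; beyond the scatter) for compound 3. Compound 3 is estimated at 6000 nM, with a range of 2500 nM to 14000 nM in this assay.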

Compound 3, concentration for 50% growth inhibition: 1450 nM
The estimate for compound 3 lay 4.1-fold (0.62 log units) above the measured number; the measured number lies below the stated range.
By their numbers in this assay, from the lowest: compound 3; then compound 2; then compound 1.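

On the nitrogen on an aromatic ring, 3-chlorophenyl gives the lowest number of the three in this assay, and the change from 4-isopropylphenyl is larger (a 9.9-fold lower number from compound 1 to compound 3 (1.00 log units; beyond the scatter)) than the earlier step suggested. The two halogen-bearing groups also separate from each other (a 3.2-fold lower number from compound 2 to compound 3 (0.50 log units; beyond the scatter)), so replacing 4-isopropylphenyl does not lead to a single level. No measurement bears on why the three groups fall in this order.

Still open, as far as these compounds go, is whether a bromine or a methoxy group in place of the chlorine would hold this gain. From the compounds shown here alone, the effect of an unsubstituted phenyl on the same nitrogen also remains unknown.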